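A few compounds are considered here, and "the series" means these few. Any claim that something is new, unique, unknown or untested is made for them only; others in the source may bear on it.

Three compounds have been measured in an in vitro assay on HEK-tsA201 cells for antagonist activity at Neuronal acetylcholine receptor; alpha4/beta2 (Homo sapiens), read by fluorescence and calcium flux; a higher number here means a weaker inhibitor, a lower number a stronger inhibitor:
Compound 1, `CCCOc1ccc(C(=O)Nc2cccc(C)n2)cc1`: 7500 nM.
Compound 2, `CCCOc1ccc(C(=O)Nc2cccc(Br)n2)cc1`: 80700 nM.
Compound 3, `CCCOc1ccc(C(=O)Nc2cccc(Cl)n2)cc1`: only a limit of the assay, > 100000 nM.

Compound 3 thus sits at the edge of what the assay can report; its value is a limit, not a number (the limit of > 100000 nM in this assay, at which 1 of the 3 values shown sits). Compound 4, `CCCOc1ccc(C(=O)Nc2cccc(CC)n2)cc1`, differs from it by a single change: ethyl in place of chloro on an aromatic carbon. The step that bears on this runs the other way round: replacing methyl with chloro gave an at least 13-fold higher number from compound 1 to compound 3 (1.12 log units; beyond the scatter), and replacing methyl with bromo gave an 11-fold higher number from compound 1 to compound 2 (1.03 log units; beyond the scatter). Putting a small alkyl back in place of the halogen is therefore expected to give a large drop in this assay, an at least 10-fold lower number from compound 3 to compound 4 (1.00 log units; beyond the scatter). Compound 4 is expected to come in near 10000 nM, between 3000 nM and 40000 nM.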

Compound 4, half-maximal inhibitory concentration: 37600 nM
Beside the measured number, compound 4's estimate is 3.8-fold (0.58 log units) below it; low and high end bracket the measured number.
By their numbers in this assay, from the lowest: compound 1; then compound 4; then compound 2. At a limit, above all of these: compound 3.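

Lengthening methyl to ethyl next to the ring nitrogen gives a 5.0-fold higher number from compound 1 to compound 4 (0.70 log units; beyond the scatter) in this assay and so shows that the outcome depends on which alkyl group sits here, not only on its replacing a halogen. Ethyl in place of bromo still gives a 2.1-fold lower number from compound 2 to compound 4 (0.33 log units; beyond the scatter) and so keeps a modest edge over that halogen. Compound 3 stands only at a limit, so an at least 2.6-fold lower number from compound 3 to compound 4 (0.42 log units; beyond the scatter) is a floor and not a full size. As far as these compounds go, whether a longer chain such as propyl, or an amine, at this position would raise or lower the number stays open.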